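Sulfamoyl for carbamoyl on the shared core of compound 2

This account rests on a few compounds, and the source may have more. Where it says the series, first, only, none or still open, it means among the compounds named here.

Compound 1 `O=C1C(Nc2ccc(-c3ccc(F)cc3)cc2)=CC(=O)c2ncncc21` gives 3200 nM in a functional assay on PANC-1 cells (Homo sapiens) for cytotoxicity, read by MTT assay, with a stated time of 72 h; on this read-out higher numbers stand for weaker inhibition and lower numbers for stronger inhibition. Compound 2 `NC(=O)c1ccc(NC2=CC(=O)c3ncncc3C2=O)cc1` gives 6300 nM in this assay, and the step of a 2.0-fold higher number from compound 1 to compound 2 (0.29 log units; within the scatter) leaves the two numbers within the scatter of each other; compound 2 and compound 1 therefore cannot be separated on the numbers shown. Compound 3 `NS(=O)(=O)c1ccc(NC2=CC(=O)c3ncncc3C2=O)cc1` carries the change (sulfamoyl in place of carbamoyl on an aromatic carbon). For the measured compounds named here, no measured step touches this group; the only step in the set, a 2.0-fold higher number from compound 1 to compound 2 (0.29 log units; within the scatter), exchanged a whole aromatic ring for the carbamoyl group and still produced no shift beyond the scatter, so a small swap of one hydrogen-bonding terminus for another is expected to leave this assay essentially unmoved. For compound 3 the number is therefore estimated at 6500 nM, lying between 2500 nM and 18000 nM, which means an expected step of a 1.0-fold higher number from compound 2 to compound 3 (0.01 log units; within the scatter).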

Compound 3, half-maximal inhibitory concentration: > 10000 nM
Compound 3: a limit, no number; the forecaster's own chance of this, stated with the estimate: 5%; middle value at least 1.5-fold (0.18 log units) away from the limit.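

In this assay compound 3 gives a limit and not a number: the limit of > 10000 nM in this assay, at which 1 of the 3 values shown sits.

On an aromatic carbon, para to a large group, sulfamoyl in place of carbamoyl gives an at least 1.5-fold higher number from compound 2 to compound 3 (0.20 log units; that floor lies within the scatter), so this swap on its own is not shown to exceed the scatter, although the limit leaves its true size unknown. Sulfamoyl in place of 4-fluorophenyl gives an at least 3.1-fold higher number from compound 1 to compound 3 (0.49 log units; beyond the scatter), the first step in the set to pass the scatter, which shows that the group at this position can change the read-out.

As far as these compounds go, how far compound 3 lies past its limit stays open. The compounds shown also leave open how a carboxylic acid or an amine on this aromatic carbon would compare with carbamoyl and sulfamoyl.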